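Styryl sulfones: growth inhibition on swapping the aryl group

The compounds below may be only part of what the source reports. "The series", "measured", "known", "first", "only" and "open" are said of these compounds alone.

Measured so far in a functional assay on PC-3 cells (Homo sapiens); a higher number here means a weaker inhibitor of growth, a lower number a stronger inhibitor of growth:
compound 1 `O=S(=O)(/C=C/c1ccc(F)cc1Cl)Cc1ccc(Nc2ncnc3ccccc23)cc1`: 100000 nM
compound 2 `O=S(=O)(/C=C/c1ccc(C(F)(F)F)cc1F)Cc1ccc(Nc2ncnc3ccccc23)cc1`: 100000 nM

Alongside compound 1, compound 2 gives 100000 nM, so the two stand level and neither leads the series. Next in line is compound 3 `O=S(=O)(/C=C/c1ccc(O)cc1)Cc1ccc(Nc2ncnc3ccccc23)cc1`, which shares the core of compound 1 and differs from compound 2 at the aryl group: 4-hydroxyphenyl in place of 2-fluoro-4-(trifluoromethyl)phenyl on a double-bonded chain carbon bound to a double-bonded chain carbon. Going by the values given here, one measured step bears on this place, no change at the digits printed from compound 1 to compound 2 (within the scatter). That step exchanged one substituted phenyl for another on the same chain carbon. Among the compounds with values here, no measured step yet shows what a 4-hydroxyphenyl group does here, so the guidance is thin. On that single step, no shift beyond the scatter is expected in this assay, though a stronger reading cannot be excluded. The expected step is a 1.4-fold lower number from compound 2 to compound 3 (0.15 log units; within the scatter). For compound 3 the estimated value is 70000 nM, with an expected range from 10000 nM to 100000 nM.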

Compound 3, concentration for 50% growth inhibition: 14000 nM
Estimate against measurement, compound 3: 5.0-fold (0.70 log units) above; low and high end bracket the measured number.
By their numbers in this assay, from the lowest: compound 3; then compounds 1 and 2 (each within the scatter of the next).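

In this assay, going by these compounds alone, the aryl group on a double-bonded chain carbon bound to a double-bonded chain carbon can move the read-out, which the first pair of halogenated aryl groups did not show: 4-hydroxyphenyl gives a 7.1-fold lower number from compound 2 to compound 3 (0.85 log units; beyond the scatter) and likewise a 7.1-fold lower number from compound 1 to compound 3 (0.85 log units; beyond the scatter). The two steps are the same size against either starting group, but each replaces the halogen substituents and introduces the hydroxyl group in a single change, so neither isolates the contribution of one substituent. No supporting measurement is available to explain the shift.

Whether the hydroxyl group itself is needed remains open, as unsubstituted phenyl, 4-methoxyphenyl and 4-aminophenyl do not appear among these compounds. Also unresolved is whether a carboxylic acid on this ring would extend the step or reverse it.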